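The compounds below may be only part of what the source reports. "The series", "measured", "known", "first", "only" and "open" are said of these compounds alone.

Among the compounds with values here, compound 3 `COC(=O)CNC(=O)CCC(=O)Oc1ccc(C[C@H]2C(=O)OC[C@@H]2Cc2ccc(OC)c(OC)c2)cc1OC` stands at the lowest of the three numbers measured so far in an ADME assay on HeLa cells (Homo sapiens) for cytotoxicity, read by MTT assay (on this read-out higher numbers stand for weaker inhibition and lower numbers for stronger inhibition), where compound 3 gives 179000 nM. Compound 1 `COc1ccc(C[C@H]2COC(=O)[C@@H]2Cc2ccc(OC(=O)CCC(=O)N3CCCC3)c(OC)c2)cc1OC` gives 201000 nM in this assay, and the change from compound 1 to compound 3 was a 1.1-fold lower number from compound 1 to compound 3 (0.05 log units; within the scatter). Within the data shown here, compound 2 `COc1ccc(C[C@H]2COC(=O)[C@@H]2Cc2ccc(OCc3cn(-c4cccc(Cl)c4)nn3)c(OC)c2)cc1OC` gives 493000 nM in this assay; no single step links compound 2 to compound 3, so its value only shows that the two differ by more than the scatter.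

Compound 4 `COc1ccc(C[C@H]2COC(=O)[C@@H]2Cc2ccc(OCC(=O)N3CCOCC3)c(OC)c2)cc1OC` differs from compound 3 in that (a group of 9 heavy atoms (6 carbon, 1 nitrogen, 2 oxygen; one six-membered non-aromatic ring with 2 hetero atoms) in place of a group of 12 heavy atoms (7 carbon, 1 nitrogen, 4 oxygen; no ring), on an oxygen on an aromatic ring). Among the measured compounds shown here, the one measured step, a 1.1-fold lower number from compound 1 to compound 3 (0.05 log units; within the scatter), exchanged a group on a carbonyl carbon and stayed within the scatter; no measured step replaces the whole group on the aromatic oxygen, so the change to compound 4 has no direct precedent. Compound 2, which carries a different group on that oxygen, gives the highest of the three numbers, but without a single-step comparison it only hints that such replacements can move the number upward. The step from compound 3 to compound 4 is therefore expected to be a 1.4-fold higher number from compound 3 to compound 4 (0.15 log units; within the scatter), small and not clearly beyond the scatter. For compound 4 the estimate in this assay is 250000 nM, with a range from 120000 nM to 600000 nM.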

Compound 4, half-maximal inhibitory concentration: >= 600000 nM
Compound 4: only a limit was reported (the forecaster's own chance of this, stated with the estimate: 15%); middle value at least 2.4-fold (0.38 log units) away from the limit.
By their numbers in this assay, from the lowest: compounds 3 and 1 (each within the scatter of the next); then compound 2. At a limit, above all of these: compound 4.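

Compound 4 gave no number in this assay, only a limit: the limit of >= 600000 nM in this assay, at which 1 of the 4 values shown sits.

Replacing the whole group on the oxygen on an aromatic ring with ((morpholin-4-yl)carbonyl)methyl produced the first single changes shown to pass beyond the scatter, an at least 3.3-fold higher number from compound 3 to compound 4 (0.52 log units; beyond the scatter) and an at least 2.9-fold higher number from compound 1 to compound 4 (0.47 log units; beyond the scatter), whereas the earlier exchange on a carbonyl carbon stayed within it. Compared with compound 2, the result is less decisive, an at least 1.2-fold higher number from compound 2 to compound 4 (0.08 log units; that floor lies within the scatter), so (morpholin-4-yl)carbonyl and 1-(3-chlorophenyl)-1H-1,2,3-triazol-4-yl on the saturated chain carbon cannot be put in order here.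

On these data alone, since compound 4 is known only through a limit, the full size of its steps remains open. Also open, as far as these compounds go, is whether the six-membered non-aromatic ring matters or whether other groups on that saturated chain carbon, such as a carboxylic acid or a piperidin-1-ylcarbonyl, would also reach the limit.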